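Two anilines on a shared diazabicyclic core, and a third

The source may hold more compounds than are shown below. What is called first, only, known or untested is meant among the compounds shown, and "the series" means these compounds.

Compound 1, `FC(F)(F)c1ccc(Nc2ccc(N3CC4CC(C3)N4)cn2)cc1`, gives 0.569 nM in an assay on cell membranes for displacement of a labelled ligand from Neuronal acetylcholine receptor; alpha4/beta2 (Rattus norvegicus); on this read-out higher numbers stand for weaker inhibition and lower numbers for stronger inhibition.
Compound 2, `Clc1cccc(Nc2ccc(N3CC4CC(C3)N4)cn2)c1`, gives 2.2 nM in this assay.

For the measured compounds named here, of the two numbers known in this assay, compound 2 has the higher one; the gap between compound 2 and compound 1 lies beyond the scatter of repeated measurements. Compound 3, `Cc1ccc(Nc2ccc(N3CC4CC(C3)N4)cn2)cc1`, has not yet been measured. It differs from compound 2 in one place: 4-methylphenyl in place of 3-chlorophenyl on a nitrogen on an aromatic ring. Going by the values given here, no measured pair here shows a step of this kind, so the size and direction of the step can only be guessed from the two values at hand. The account expects compound 3 to sit between the two measured compounds, since compound 1 with its own aryl group gives 0.569 nM while compound 2 gives 2.2 nM. The estimated step of a 1.8-fold lower number from compound 2 to compound 3 (0.26 log units; within the scatter) is expected to be modest, toward a lower number. Compound 3 is therefore estimated at 1.2 nM, within a range from 0.35 nM to 4 nM.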

Compound 3, inhibition constant: 52.1 nM
Estimate against measurement, compound 3: 43-fold (1.64 log units) below; measured number outside the range, above it.
By their numbers in this assay, from the lowest: compound 1; then compound 2; then compound 3.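

In this assay this aryl group proves far more sensitive than the first two compounds could show: methyl in place of trifluoromethyl on an aromatic carbon, with the rest of the molecule unchanged, gives a 92-fold higher number from compound 1 to compound 3 (1.96 log units; beyond the scatter) as its result. The change to 4-methylphenyl from 3-chlorophenyl on a nitrogen on an aromatic ring gives a 24-fold higher number from compound 2 to compound 3 (1.37 log units; beyond the scatter) even though the heavy-atom count stays the same, and this step alters both the substituent and where it sits on the ring. Nothing presented here accounts for the size of either step.

Going by these compounds, how much of the second step belongs to the substituent and how much to its place remains open, and 3-methylphenyl and 4-chlorophenyl would be needed to separate the two. Also open, on these data alone, is how a methoxy group, a nitrile or an amine on this ring would read.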